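Nitrophenyl in place of octyl on a quinazoline-type amine

The source may report more compounds than this note shows. Statements on the series, on what has been measured and on what is new or still open speak of the compounds shown alone.

Measured compounds:
Compound 1 `CCCCCCCCNc1nc(SCc2ccc(C(F)(F)F)cc2)nc2ccccc12`: 22300 nM
Compound 2 `O=[N+]([O-])c1cccc(Nc2nc(SCc3ccc(C(F)(F)F)cc3)nc3ccccc23)c1`: 31500 nM

In a functional assay on MDA-MB-231 cells (Homo sapiens) for cytotoxicity, read by MTT assay, with a stated time of 72 h (on this read-out lower numbers stand for stronger inhibition and higher numbers for weaker inhibition), compound 1 gives 22300 nM, and compound 2 gives 31500 nM; the two values sit within the scatter of each other, as the step of a 1.4-fold higher number from compound 1 to compound 2 (0.15 log units; within the scatter) shows. Compound 3 `O=[N+]([O-])c1ccc(Nc2nc(SCc3ccc(C(F)(F)F)cc3)nc3ccccc23)cc1` has not been measured in this assay. It differs from compound 1 in one place: 4-nitrophenyl in place of octyl on a nitrogen on an aromatic ring. Among the measured compounds shown here, the only step that bears on this change is the one from compound 1 to compound 2, where an aryl group also replaced the octyl chain and the number barely moved. Compound 3 is therefore expected to show no step beyond the scatter, a 1.3-fold higher number from compound 1 to compound 3 (0.10 log units; within the scatter), and its value is estimated at 28000 nM, between 12000 nM and 65000 nM.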

Compound 3, half-maximal inhibitory concentration: 8670 nM
Compound 3: the middle estimate sits 3.2-fold (0.51 log units) above what was measured; measured number outside the range, below it.
By their numbers in this assay, from the lowest: compound 3; then compounds 1 and 2 (each within the scatter of the next).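

In this assay swapping octyl for an aryl group on this nitrogen can shift the number after all, as the step of a 2.6-fold lower number from compound 1 to compound 3 (0.41 log units; beyond the scatter) goes beyond the scatter, which 3-nitrophenyl did not do. The two nitrophenyl groups also differ from each other, with a 3.6-fold lower number from compound 2 to compound 3 (0.56 log units; beyond the scatter) showing that where the nitro group sits on the phenyl ring matters here. No evidence at hand explains this difference. Still open, on these data alone, is whether a nitrile or a carboxylic acid in place of the nitro group of compound 3 would keep the lower number. Also open, as far as these compounds go, is whether an unsubstituted phenyl would behave like 4-nitrophenyl or like 3-nitrophenyl.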